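Aryl replacement in a growth-inhibition series

This account rests on a few compounds, and the source may have more. Where it says the series, first, only, none or still open, it means among the compounds named here.

Measured so far in a functional assay on MCF7 cells (Homo sapiens); on this read-out higher numbers stand for weaker inhibition of growth and lower numbers for stronger inhibition of growth
- compound 1 `O=S(=O)(/C=C/c1ccc(Cl)c(Cl)c1)Cc1ccc(Nc2ncnc3ccccc23)cc1` gives 28000 nM as its value
- compound 2 `O=S(=O)(/C=C/c1ccc(Br)cc1)Cc1ccc(Nc2ncnc3ccccc23)cc1` gives 91000 nM as its value

Compound 2 holds the higher of the two numbers, and compound 1 is its nearest neighbour. Compound 3 `O=S(=O)(/C=C/c1ccc(C(F)(F)F)cc1F)Cc1ccc(Nc2ncnc3ccccc23)cc1` has 2-fluoro-4-(trifluoromethyl)phenyl in place of 4-bromophenyl on a double-bonded chain carbon bound to a double-bonded chain carbon on a double-bonded chain carbon bound to a double-bonded chain carbon. Among the compounds with values here, one measured step bears on this place, the modest 3.3-fold higher number from compound 1 to compound 2 (0.51 log units; beyond the scatter) at the same carbon. With compound 2 at 91000 nM as the top of a short range, a modest move to a lower number is expected in this assay and it may stay within the scatter. The expected change is a 1.7-fold lower number from compound 2 to compound 3 (0.22 log units; within the scatter) as estimated here. For compound 3 the estimate is 55000 nM with an expected range of 18000 nM to 150000 nM for now.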

Compound 3, concentration for 50% growth inhibition: 100000 nM
Beside the measured number, compound 3's estimate is 1.8-fold (0.26 log units) below it; the range from low to high includes it.
By their numbers in this assay, from the lowest: compound 1; then compounds 2 and 3 (each within the scatter of the next).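

At this carbon, in this assay, 2-fluoro-4-(trifluoromethyl)phenyl and 4-bromophenyl are not separated, with a 1.1-fold higher number from compound 2 to compound 3 (0.04 log units; within the scatter) lying within the scatter despite the different substituents. The 3,4-dichlorophenyl group of compound 1 is now set apart from a second aryl group, with a 3.6-fold higher number from compound 1 to compound 3 (0.55 log units; beyond the scatter) lying beyond the scatter, so compound 1 alone stands apart among the three. Nothing at hand explains this difference. Still open, as far as these compounds go, is whether an amine or a carboxylic acid on the aryl group at this carbon would stay with compound 2 and compound 3 or move toward compound 1.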